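The compounds below may be only part of what the source reports. "The series", "measured", "known", "first", "only" and "open" are said of these compounds alone.

Compound 1 `O=C(CCCCC1CCCCC1)OCC1COCCOCCOCCOCCO1` and compound 2 `O=C(CCCCC1CCCCC1)OCC1COCCOCCOCCOCCOCCO1` share the ester core with the cyclic ether. In a functional assay on SW1573 cells (Homo sapiens) for inhibition, read by sulforhodamine B assay, with a stated time of 48 h (on this read-out lower numbers stand for stronger inhibition of growth and higher numbers for weaker inhibition of growth), compound 1 gives > 100000 nM, which is a limit of the assay and not a number (the limit of > 100000 nM in this assay, at which 1 of the 2 values shown sits). In this assay, going by the values given here, compound 2 gives 51000 nM, the only number among the two values shown. Compound 3 `O=C(CCCCc1ccccc1)OCC1COCCOCCOCCOCCOCCO1` differs from compound 2 by phenyl in place of cyclohexyl on a saturated chain carbon, four bonds along the chain from a carbonyl carbon. Among the compounds with values here, no measured step of this kind is available, so the step from compound 2 to compound 3 is expected to stay within the scatter, with a slight lean to weaker growth inhibition: a 1.4-fold higher number from compound 2 to compound 3 (0.14 log units; within the scatter). Compound 3 is therefore estimated at 70000 nM, between 30000 nM and 150000 nM.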

Compound 3, concentration for 50% growth inhibition: > 100000 nM
Compound 3 gave a limit, no number; the forecaster's own chance of this, stated with the estimate: 30%; at least 1.4-fold (0.15 log units) between middle value and limit.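

Phenyl in place of cyclohexyl gives the first readable step at this position in this assay (an at least 1.9-fold higher number from compound 2 to compound 3 (0.29 log units; that floor lies within the scatter)). On these data alone, the value of compound 3 is a limit of the assay and not a number, so the true size of the step remains unknown and the change cannot be placed beyond the scatter. With this result, most of the values shown sit at the limit: the limit of > 100000 nM in this assay, at which 2 of the 3 values shown sit.

As far as these compounds go, whether an amine or a carboxylic acid in place of cyclohexyl, or a longer chain carrying cyclohexyl, would give stronger growth inhibition stays open.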